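Swapping the Thiazole Ring for a Dichlorinated Six-Membered Ring

The compounds below may be only part of what the source reports. "The series", "measured", "known", "first", "only" and "open" are said of these compounds alone.

Compound 1 `COc1ccc(C(=O)Nc2ccccc2F)cc1OC1CCCC1`: 10700 nM
Compound 2 `COc1ccc(C(=O)Nc2nccs2)cc1OC1CCCC1`: 6500 nM

Both compounds were tested in an assay on isolated protein for inhibition of phosphodiesterase 4A (Sus scrofa); a higher number here means a weaker inhibitor, a lower number a stronger inhibitor. In this assay compound 1 gives 10700 nM, and compound 2 gives 6500 nM. For the measured compounds named here, the only measured step, a 1.6-fold lower number from compound 1 to compound 2 (0.22 log units; within the scatter), lies within the scatter, so the two values cannot be told apart in any direction; compound 2 simply stands at the value it gives, with compound 1 alongside it.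

Compound 3 `COc1ccc(C(=O)NN2C(Cl)=NC=CC2Cl)cc1OC1CCCC1` differs from compound 2 in one place: a group of 8 heavy atoms (4 carbon, 2 nitrogen, 2 chlorine; one six-membered non-aromatic ring with 2 hetero atoms) in place of a group of 5 heavy atoms (3 carbon, 1 nitrogen, 1 sulfur; one five-membered aromatic ring with 2 hetero atoms), on an amide-type nitrogen. Going by the values given here, the one step measured so far also exchanges the group on this amide-type nitrogen, and it left the number essentially unchanged. Among the compounds with values here, the new group, however, resembles neither of the groups already tried, so there is no direct precedent for it in the data. The expectation is therefore a step of a 1.2-fold higher number from compound 2 to compound 3 (0.09 log units; within the scatter), with little confidence about direction and a wide range around it. For compound 3 the estimate in this assay is 8000 nM, with the likely range running from 2500 nM to 25000 nM.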

Compound 3, half-maximal inhibitory concentration: 400 nM
The estimate for compound 3 lay 20-fold (1.30 log units) above the measured number; the measured number lies below the stated range.
By their numbers in this assay, from the lowest: compound 3; then compounds 2 and 1 (each within the scatter of the next).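

In this assay, putting the dichlorinated six-membered non-aromatic ring on the amide-type nitrogen gives a 16-fold lower number from compound 2 to compound 3 (1.21 log units; beyond the scatter) and a 27-fold lower number from compound 1 to compound 3 (1.43 log units; beyond the scatter), and both steps lie beyond the scatter. The earlier exchange at this nitrogen, a 1.6-fold lower number from compound 1 to compound 2 (0.22 log units; within the scatter), stayed within the scatter, so the position looked insensitive until now, yet compound 3 shows that the group placed here can shift the number by a large amount and stands clearly lowest of the three. Nothing available explains this large drop, which remains an observation without a known cause.

The new group differs from the 1,3-thiazol-2-yl and 2-fluorophenyl groups in several ways at once, including its ring size, its non-aromatic ring and its two chlorine atoms, so the compounds shown cannot say which of these features matters. On these data alone, a version of the same ring with methyl groups or plain hydrogen in place of the chlorines would begin to separate these features, and whether the effect carries over to other changes on the shared core remains open.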